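Aryl variation on the enone chain: expectation for compound 4

This account rests on a few compounds, and the source may have more. Where it says the series, first, only, none or still open, it means among the compounds named here.

Three compounds share one core. In an ADME assay on the whole organism for cytotoxicity, with Artemia salina as the target, with a stated time of 24 h (a higher number here means that more compound is needed for the effect, a lower number that less compound is needed), compound 1 `Cc1ccc(S(=O)(=O)NC(=O)Nc2ccccc2C(=O)/C=C/c2ccc(N(C)C)cc2)cc1` gives 38.1 ug/mL; compound 2 `COc1ccc(/C=C/C(=O)c2ccccc2NC(=O)NS(=O)(=O)c2ccc(C)cc2)cc1OC` gives 12.9 ug/mL; compound 3 `Cc1ccc(S(=O)(=O)NC(=O)Nc2ccccc2C(=O)/C=C/c2cccc([N+](=O)[O-])c2)cc1` gives 44.5 ug/mL. Compound 2 stands lowest of the three, both others beyond the scatter from it: a 3.0-fold lower number from compound 1 to compound 2 (0.47 log units; beyond the scatter) and a 3.4-fold higher number from compound 2 to compound 3 (0.54 log units; beyond the scatter). Compound 4 `Cc1ccc(S(=O)(=O)NC(=O)Nc2ccccc2C(=O)/C=C/c2cc(O)ccc2[N+](=O)[O-])cc1` is compound 2 with one change: 5-hydroxy-2-nitrophenyl in place of 3,4-dimethoxyphenyl on a double-bonded chain carbon bound to a double-bonded chain carbon. Both measured steps at this place bear on it, and both were modest. Compound 3, which also carries a nitrophenyl at this place, lies beyond the scatter above compound 2. A modest upward step is therefore expected in this assay, beyond the scatter: a 2.7-fold higher number from compound 2 to compound 4 (0.43 log units; beyond the scatter). Compound 4 is estimated at 35 ug/mL, with a range of 15 ug/mL to 80 ug/mL.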

Compound 4, concentration for half-maximal effect: 18.3 ug/mL
Estimate against measurement, compound 4: 1.9-fold (0.28 log units) above; the range from low to high includes it.
By their numbers in this assay, from the lowest: compounds 2 and 4 (each within the scatter of the next); then compounds 1 and 3 (each within the scatter of the next).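

A nitrophenyl at this place does not by itself give a high number: 5-hydroxy-2-nitrophenyl gives a 2.4-fold lower number from compound 3 to compound 4 (0.39 log units; beyond the scatter), and likewise a 2.1-fold lower number from compound 1 to compound 4 (0.32 log units; beyond the scatter). It also stays level with 3,4-dimethoxyphenyl, with a 1.4-fold higher number from compound 2 to compound 4 (0.15 log units; within the scatter), so two differently substituted phenyl groups now share the low end of the series. No evidence on the origin of these differences is at hand.

Still open, as far as these compounds go, is whether the hydroxy group or the nitro placement separates compound 3 from compound 4; the two differ in both. From the compounds shown here alone, how a carboxylic acid or a primary amine on the phenyl at this place would read also remains open.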